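Swapping chloro for methoxy on the side ring

This account rests on a few compounds, and the source may have more. Where it says the series, first, only, none or still open, it means among the compounds named here.

Measured so far:
- compound 1, `CCCCCCCCCCCCCCCCNCn1nc(-c2ccc3c(c2)OCCO3)oc1=S`: 22900 nM
- compound 2, `S=c1oc(-c2ccc3c(c2)OCCO3)nn1CNc1ccccc1Cl`: 7230 nM

Of the compounds shown here, two share the same core and have been tested in a functional assay, with a stated time of 6 min; a lower number here means a stronger inhibitor, a higher number a weaker inhibitor. Compound 1, `CCCCCCCCCCCCCCCCNCn1nc(-c2ccc3c(c2)OCCO3)oc1=S`, gives 22900 nM in this assay. Compound 2, `S=c1oc(-c2ccc3c(c2)OCCO3)nn1CNc1ccccc1Cl`, gives 7230 nM, the lowest of the two numbers; compound 1 sits a clearly weaker step away, beyond the usual scatter of this assay. The two compounds differ in more than one place, so their gap cannot be pinned on a single change.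

Compound 3, `COc1ccccc1NCn1nc(-c2ccc3c(c2)OCCO3)oc1=S`, has not yet been measured. Its relation to compound 2 is a single change: methoxy in place of chloro on an aromatic carbon. Among the measured compounds shown here, nothing among the measured compounds shows what such a swap does here, so no step size is known. The expectation is a step from compound 2 to compound 3 of a 1.2-fold higher number from compound 2 to compound 3 (0.10 log units; within the scatter), that is, a small movement toward a weaker number, close to the scatter. Compound 3 is therefore estimated at 9000 nM, with a plausible range from 3000 nM to 30000 nM.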

Compound 3, half-maximal inhibitory concentration: 6300 nM
Beside the measured number, compound 3's estimate is 1.4-fold (0.15 log units) above it; low and high end bracket the measured number.
By their numbers in this assay, from the lowest: compounds 3 and 2 (each within the scatter of the next); then compound 1.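

Read in this assay, the swap from 2-chlorophenyl to 2-methoxyphenyl is a 1.1-fold lower number from compound 2 to compound 3 (0.06 log units; within the scatter) and so cannot be told apart from no effect at all. Among the compounds shown here, this is the first single-change comparison, and it shows that this aromatic carbon, ortho to a large group, can carry either chloro or methoxy while the two compounds read alike, even though methoxy has one more heavy atom and brings a hydrogen-bond acceptor that chloro lacks. Nothing measured here bears on why the two groups read alike.

For the compounds shown here, with only two groups compared at this carbon, it remains open whether the reading would hold for a plain hydrogen, an amine or a carboxylic acid in the same place, and so whether this carbon tolerates almost any group or only ones like these two. As far as these compounds go, it is also open whether chloro and methoxy would still read alike at the other carbons of this ring, or whether the same swap would behave in the same way on a different core.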